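Working notes: replacing ethoxycarbonyl with hydroxymethyl on compound 2

The source may report more compounds than this note shows. Statements on the series, on what has been measured and on what is new or still open speak of the compounds shown alone.

Compound 1 `CCO/C(O)=C/C1=N[C@]2(CCC1)CCC[C@@H]2CO[Si](c1ccccc1)(c1ccccc1)C(C)(C)C` gives > 100000 nM as a limit
Compound 2 `CCOC(=O)C[C@H]1CCC[C@]2(CCC[C@@H]2CO[Si](c2ccccc2)(c2ccccc2)C(C)(C)C)N1` gives 40000 nM as a number

Both values come from a functional assay on THP-1 cells (Homo sapiens) for cytotoxicity (a lower number here means a stronger inhibitor, a higher number a weaker inhibitor), and the series has no others so far. The entry for compound 1 at > 100000 nM is a limit of the assay and not a number. Within the data shown here, compound 2 holds the only true number at 40000 nM in this series.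

The next step leads to compound 3 `CC(C)(C)[Si](OC[C@H]1CCC[C@]12CCC[C@H](CCO)N2)(c1ccccc1)c1ccccc1` and keeps the shared core. The change is hydroxymethyl in place of ethoxycarbonyl on a saturated chain carbon bound to a saturated ring carbon and reads in words as hydroxymethyl in place of ethoxycarbonyl on a saturated chain carbon bound to a saturated ring carbon. Cut one bond further out, it is (ethoxycarbonyl)methyl to 2-hydroxyethyl.

Among the measured compounds shown here, no measured pair shows this change, so the expectation rests on compound 2 at 40000 nM alone. In this assay no step beyond the scatter is expected, and the direction is not firmly set. The expected step is a 1.3-fold lower number from compound 2 to compound 3 (0.12 log units; within the scatter) on this estimate. For compound 3 the estimated value is 30000 nM with an expected range from 10000 nM to 80000 nM in this assay.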

Compound 3, half-maximal inhibitory concentration: 8900 nM
Compound 3: the middle estimate sits 3.4-fold (0.53 log units) above what was measured, outside the stated range (below it).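

In this assay, hydroxymethyl in place of ethoxycarbonyl on a saturated chain carbon bound to a saturated ring carbon gives a 4.5-fold lower number from compound 2 to compound 3 (0.65 log units; beyond the scatter) and so moves the value beyond the usual scatter. Among these compounds, this is the first step that can be read between two true numbers in compounds differing in one place, and it shows that this position does respond to a change of group, with (ethoxycarbonyl)methyl giving way to 2-hydroxyethyl and the number falling. Compound 1 carries a limit of the assay and not a number, and the series still sits in a high range of values: the limit of > 100000 nM in this assay, at which 1 of the 3 values shown sits.

A single pair cannot separate the departure of the ethoxycarbonyl from the arrival of the hydroxymethyl, so the step is tied to the whole exchange and not to either group alone. From the compounds shown here alone, whether a carboxylic acid, an amine or a longer chain ending in a hydroxyl group on the same saturated chain carbon would extend the step, hold it or reverse it remains open.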